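Replacing a Fluorinated Diol with Acetyl on a Shared Core

The source may hold more compounds than are shown below. What is called first, only, known or untested is meant among the compounds shown, and "the series" means these compounds.

Compound 1 `CC#C[C@H]1CN(S(=O)(=O)c2ccc(N)nc2)CCN1c1ccc([C@@](O)(CO)C(F)(F)F)cc1` is measured in an ADME assay (liver) for metabolic stability, with Liver microsome (Rattus norvegicus) as the target, using microsomes and NADPH, with a stated time of 30 min (a higher number here means faster removal of the compound, a lower number slower removal), and gives 53 mL.min-1.g-1, the lower of the two numbers in hand. Compound 2 `CC#CCC(O)(c1ccc(N2CCN(S(=O)(=O)c3ccc(N)nc3)C[C@@H]2C#CC)cc1)C(F)(F)F` gives 115 mL.min-1.g-1, and the step of a 2.2-fold higher number from compound 1 to compound 2 (0.34 log units; beyond the scatter) alters the same aromatic carbon that is at issue here. Compound 3 `CC#C[C@H]1CN(S(=O)(=O)c2ccc(N)nc2)CCN1c1ccc(C(C)=O)cc1` differs from compound 1 by a group of 3 heavy atoms (2 carbon, 1 oxygen; no ring) in place of a group of 8 heavy atoms (3 carbon, 2 oxygen, 3 fluorine; no ring), on an aromatic carbon. Going by the values given here, with only that modest step at this position to go on, a change of similar size in this assay is expected, most likely upward, so compound 3 is estimated at 75 mL.min-1.g-1 (range 30 mL.min-1.g-1 to 180 mL.min-1.g-1), a step of a 1.4-fold higher number from compound 1 to compound 3 (0.15 log units; within the scatter).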

Compound 3, intrinsic clearance in microsomes: 249 mL.min-1.g-1
The estimate for compound 3 lay 3.3-fold (0.52 log units) below the measured number; the measured number lies above the stated range.
By their numbers in this assay, from the lowest: compound 1; then compound 2; then compound 3.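

In this assay, acetyl on this aromatic carbon, para to a large group, gives the highest number of the three (a 4.7-fold higher number from compound 1 to compound 3 (0.67 log units; beyond the scatter); a 2.2-fold higher number from compound 2 to compound 3 (0.34 log units; beyond the scatter)). Going by these compounds alone, the earlier step compared only two fluorine-bearing groups, whereas this result shows that acetyl, which has no fluorine and no hydrogen-bond donor, stands above both. Nothing available accounts for this order. As far as these compounds go, it remains open whether a smaller alcohol, a primary amide or a carboxylic acid at this position would stand nearer compound 1 or compound 3. The compounds also leave open whether this order holds on another core.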